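The source may report more compounds than this note shows. Statements on the series, on what has been measured and on what is new or still open speak of the compounds shown alone.

Three compounds share one core. Compound 1 `CCc1ccccc1N(Cc1nnc(Cc2ccc(OC)cc2)o1)S(=O)(=O)c1ccc(C)cc1` gives 631 nM in a functional assay on CHO cells for antagonist activity at prostaglandin E2 receptor EP1 subtype (Homo sapiens), read by FLIPR and calcium flux; a lower number here means a stronger inhibitor, a higher number a weaker inhibitor. Compound 2 `Cc1ccc(S(=O)(=O)N(Cc2nnc(Cc3ccc(N(C)C)cc3)o2)c2cccc(Cl)c2C)cc1` gives 20 nM. Compound 3 `Cc1ccc(S(=O)(=O)N(Cc2nnc(Cc3ccc(C(F)(F)F)cc3)o2)c2cccc(Cl)c2C)cc1` gives 158 nM, the second highest of the three numbers; its nearest neighbour is compound 1, whose number lies above it, and its furthest is compound 2, whose number lies below it. Among the measured compounds shown here, the one single-point step among the measured compounds, a 7.9-fold higher number from compound 2 to compound 3 (0.90 log units; beyond the scatter), altered the group on the benzyl part of the shared core. Compound 4 `Cc1ccc(S(=O)(=O)N(Cc2nnc(Cc3cccc(F)c3)o2)c2cccc(Cl)c2C)cc1` differs from compound 3 in that same benzyl part: 3-fluorophenyl in place of 4-(trifluoromethyl)phenyl on a saturated chain carbon bound to an aromatic carbon. For the measured compounds named here, only the step from compound 2 to compound 3 bears on this change, and it shows that the group carried on the benzyl part can move the number substantially; yet no 3-fluorophenyl variant has been measured here, so the direction remains open. A step smaller than that measured one is therefore expected in this assay, a 1.6-fold lower number from compound 3 to compound 4 (0.20 log units; within the scatter). Compound 4 is expected to give 100 nM, with a range from 30 nM to 400 nM.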

Compound 4, inhibition constant: 501 nM
For compound 4 the middle estimate is 5.0-fold (0.70 log units) below the measured one; measured number above the stated range.
By their numbers in this assay, from the lowest: compound 2; then compound 3; then compounds 4 and 1 (each within the scatter of the next).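

In this assay, a 3.2-fold higher number from compound 3 to compound 4 (0.50 log units; beyond the scatter) shows that this position responds even when one fluorine-bearing phenyl group on a saturated chain carbon bound to an aromatic carbon replaces another. With a 25-fold higher number from compound 2 to compound 4 (1.40 log units; beyond the scatter), the range at this position widens, and among the three compounds that differ only here, 4-(dimethylamino)phenyl gives the lowest number and 3-fluorophenyl the highest. Nothing available accounts for either step.

As far as these compounds go, what 4-fluorophenyl or 3-(trifluoromethyl)phenyl would give on the same core remains open, so the change of group cannot yet be separated from the change in where it sits on the ring. From the compounds shown here alone, it is also open whether a simple amine such as 4-aminophenyl would match the low number of compound 2 or whether that number is particular to the dimethylamino group.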